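Working notes: thiophen-3-yl for bromo on compound 2

The source may report more compounds than this note shows. Statements on the series, on what has been measured and on what is new or still open speak of the compounds shown alone.

In a functional assay on MIA PaCa-2 cells (Homo sapiens) for antiproliferative activity, read by MTT assay, with a stated time of 72 h (on this read-out lower numbers stand for stronger inhibition and higher numbers for weaker inhibition), the measured compounds read as follows.
- Compound 1 `O=C(Nc1ccccn1)c1cc(=O)[nH]c2cc(Br)ccc12` gives 21300 nM
- Compound 2 `O=C(Nc1cccc(F)c1)c1cc(=O)[nH]c2cc(Br)ccc12` gives 7500 nM
- Compound 3 `O=C(Nc1cc(F)cc(F)c1)c1cc(=O)[nH]c2cc(Br)ccc12` gives 7800 nM

Compound 2 stands at the low end of these numbers, together with compound 3, from which it cannot be separated, while compound 1 lies clearly higher. The next compound is compound 4 `O=C(Nc1cccc(F)c1)c1cc(=O)[nH]c2cc(-c3ccsc3)ccc12`, which carries thiophen-3-yl in place of bromo on an aromatic carbon.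

Both measured steps sit on the amide side, and neither touches the carbon carrying bromo. There is a 2.8-fold lower number from compound 1 to compound 2 (0.45 log units; beyond the scatter) with 3-fluorophenyl in place of pyridin-2-yl, a modest step, and a 1.0-fold higher number from compound 2 to compound 3 (0.02 log units; within the scatter) with fluoro in place of hydrogen on an aromatic carbon. These steps show only the sizes seen so far, since every measured compound keeps bromo at this place. A modest step toward a lower number is therefore expected in this assay, though the direction rests on little and a step within the scatter stays possible. The estimate means a 2.5-fold lower number from compound 2 to compound 4 (0.40 log units; beyond the scatter) as the expected step. Compound 4 is estimated at 3000 nM with an expected range from 800 nM to 11000 nM (in this assay).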

Compound 4, half-maximal inhibitory concentration: 4500 nM
For compound 4 the middle estimate is 1.5-fold (0.18 log units) below the measured one; low and high end bracket the measured number.
By their numbers in this assay, from the lowest: compounds 4, 2 and 3 (each within the scatter of the next); then compound 1.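

In this assay, among these compounds, the first change at the carbon that carries bromo, thiophen-3-yl in place of bromo, gives a 1.7-fold lower number from compound 2 to compound 4 (0.22 log units; within the scatter) and so cannot be told apart from no change on this read-out. Among the compounds shown here, every earlier compound kept bromo here, so the earlier compounds gave no reading at this place; this result shows that the single bromine atom can give way to the five heavy atoms of thiophen-3-yl, with its five-membered aromatic ring, while the number stays within the scatter of that of compound 2. Nothing measured in this series offers a reason for this outcome.

From the compounds shown here alone, what remains open is whether groups of another kind on this aromatic carbon, such as an amine, a carboxylic acid or a longer alkyl chain, would also stay within the scatter, since one replacement describes only itself. Also open, going by these compounds, is whether the amide-side difference, a 2.8-fold lower number from compound 1 to compound 2 (0.45 log units; beyond the scatter), which has been read only with bromo on the core, would carry over with thiophen-3-yl in its place.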